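Aryl group on the aromatic nitrogen: compound 4 expected

A few compounds are considered here, and "the series" means these few. Any claim that something is new, unique, unknown or untested is made for them only; others in the source may bear on it.

Three measured compounds share one core and differ only in their aryl groups. Compound 1 `COc1ccc(-n2nc(-c3ccccc3)nc2CNc2ccc(C(=O)NO)cc2)cc1` gives 63.4% in an assay on Sf9 cells for inhibition of protein deacetylase HDAC6 (Homo sapiens), read by fluorescence, with a stated time of 40 min, tested at 100 nM; on this read-out lower numbers stand for less inhibition and higher numbers for more inhibition at the one concentration tested (going by the name of the read-out). Compound 2 `O=C(NO)c1ccc(NCc2nc(-c3ccc(Cl)cc3)nn2-c2ccccc2)cc1` gives 67.2% in this assay, and compound 3 `O=C(NO)c1ccc(NCc2nc(-c3ccccc3)nn2-c2ccc(Br)cc2)cc1` gives 65.9% there. On these numbers compound 3 stands second highest of the three, nearest to compound 2 and furthest from compound 1, both gaps within the scatter. Among the measured compounds shown here, the one measured step at the group on the aromatic nitrogen, a number 2.5 percentage points higher from compound 1 to compound 3 (within the scatter), is itself within the scatter.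

Compound 4 `Cc1cccc(-n2nc(-c3ccccc3)nc2CNc2ccc(C(=O)NO)cc2)c1` differs from compound 3 at that same place: 3-methylphenyl in place of 4-bromophenyl on an aromatic nitrogen. This step bears directly on the earlier one, since compound 1 and compound 3 also differ only in the aryl on the aromatic nitrogen. Because a number 2.5 percentage points higher from compound 1 to compound 3 (within the scatter) stayed within the scatter, no step beyond the scatter is expected for compound 4 either. The expected step is a number 1.9 percentage points lower from compound 3 to compound 4 (within the scatter). Compound 4 is therefore estimated at 64%, within a range from 52% to 76%.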

Compound 4, a percentage reported as inhibition, at one concentration (the size of the read-out at that concentration, not a potency): 66%
Estimate against measurement, compound 4: 2 percentage points below, within the range that was stated.
By their numbers in this assay, from the lowest: compounds 1, 3, 4 and 2 (each within the scatter of the next).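

In this assay, 3-methylphenyl in place of 4-bromophenyl on the aromatic nitrogen gives a number 0.1 percentage points higher from compound 3 to compound 4 (within the scatter) and, against the 4-methoxyphenyl group, a number 2.6 percentage points higher from compound 1 to compound 4 (within the scatter) as well. The earlier compounds shown here gave a single step at this position, whereas three aryl groups can now be compared there, and the read-out does not separate them: the 4-bromo, 4-methoxy and 3-methyl forms all lie within the scatter of one another. No evidence is available on what underlies this result.

Open, as far as these compounds go, is whether an amine or a carboxylic acid on this aryl group, or a longer chain in its place, would give a step beyond the scatter. The compounds shown also leave potency undefined, as this assay reports one concentration only, and they give no reading on any other deacetylase.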